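Series notes: amide-for-methyl swap on the piperazine

This account rests on a few compounds, and the source may have more. Where it says the series, first, only, none or still open, it means among the compounds named here.

Compound 2 `COc1ccc2c(c1F)C(=O)N(C[C@@]1(c3cc4nc(N5CCN(C)CC5)ccc4o3)NC(=O)N(COC(=O)C(C)(C)C)C1=O)C2` stands highest of the two numbers in hand, though within the scatter of compound 1 `CCN1CCN(c2ccc3oc([C@]4(CN5Cc6ccc(OC)c(F)c6C5=O)NC(=O)N(COC(=O)C(C)(C)C)C4=O)cc3n2)CC1`. In an ADME assay on the whole organism for pharmacokinetics, with Rattus norvegicus as the target, read by LC-MS, at a dose of 10 mg/kg by the oral route (a higher number here means more compound in the circulation at the dose given, a lower number less compound in the circulation), compound 2 gives 934 ng.h/mL; compound 1 gives 764 ng.h/mL. In this assay compound 3 `COc1ccc2c(c1)C(=O)N(C[C@@]1(c3cc4nc(N5CCNCC5)ccc4o3)NC(=O)N(COC(=O)C(C)(C)C)C1=O)C2` gives "not determined" (no result reported). Going by the values given here, the only measured step, a 1.2-fold higher number from compound 1 to compound 2 (0.09 log units; within the scatter), concerns a change elsewhere on the molecule and bears only loosely on compound 4 `COc1ccc2c(c1F)C(=O)N(C[C@@]1(c3cc4nc(N5CCNC(=O)C5)ccc4o3)NC(=O)N(COC(=O)C(C)(C)C)C1=O)C2`, which differs from compound 2 by 3-oxopiperazin-1-yl in place of 4-methylpiperazin-1-yl on an aromatic carbon. Among the compounds with values here, no measured step covers this change, so no direction beyond the scatter is predicted; a step of a 1.2-fold lower number from compound 2 to compound 4 (0.07 log units; within the scatter) is expected, with a wide range. Compound 4 is estimated at 800 ng.h/mL, between 250 ng.h/mL and 2500 ng.h/mL.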

Compound 4, area under the concentration-time curve: 62.3 ng.h/mL
The estimate for compound 4 lay 13-fold (1.11 log units) above the measured number; the whole stated range lies above it.
By their numbers in this assay, from the lowest: compound 4; then compounds 1 and 2 (each within the scatter of the next).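

In this assay the group on this aromatic carbon proves decisive: 3-oxopiperazin-1-yl in place of 4-methylpiperazin-1-yl gives a 15-fold lower number from compound 2 to compound 4 (1.18 log units; beyond the scatter), and in place of 4-ethylpiperazin-1-yl it gives a 12-fold lower number from compound 1 to compound 4 (1.09 log units; beyond the scatter). The earlier methyl and ethyl pair stayed within the scatter, so only the replacement by the 3-oxopiperazin-1-yl ring shows a large step at this position. No measurement shown accounts for the drop.

The compounds shown leave open how a morpholin-4-yl or a 4-acetylpiperazin-1-yl group on this carbon would compare.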